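The source may report more compounds than this note shows. Statements on the series, on what has been measured and on what is new or still open speak of the compounds shown alone.

Measured in a functional assay on MCF7 cells (Homo sapiens) for cytotoxicity, read by MTT assay, with a stated time of 72 h; a lower number here means a stronger inhibitor, a higher number a weaker inhibitor:
Compound 1, `CN1[C@@H]2c3[nH]c4ccccc4c3C[C@H]1[C@H](C#N)N1[C@@H](CN3C(=O)c4ccccc4C3=O)c3[nH]c4ccccc4c3C[C@@H]21`, gives 610 nM
Compound 2, `CN1[C@@H]2c3[nH]c4ccccc4c3C[C@H]1[C@H](C#N)N1[C@@H](CNC(=O)c3ccc(Cl)cc3)c3[nH]c4ccccc4c3C[C@@H]21`, gives 610 nM
Compound 3, `COc1ccc(C(=O)NC[C@H]2c3[nH]c4ccccc4c3C[C@H]3[C@H]4c5[nH]c6ccccc6c5C[C@@H]([C@H](C#N)N23)N4C)cc1`, gives 600 nM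

Compound 3 holds the lowest of these three numbers, yet the others lie within the scatter of it: a 1.0-fold lower number from compound 1 to compound 3 (0.01 log units; within the scatter) and a 1.0-fold lower number from compound 2 to compound 3 (0.01 log units; within the scatter). Compound 4, `CCc1ccc(C(=O)NC[C@H]2c3[nH]c4ccccc4c3C[C@H]3[C@H]4c5[nH]c6ccccc6c5C[C@@H]([C@H](C#N)N23)N4C)cc1`, differs from compound 3 in one place: ethyl in place of methoxy on an aromatic carbon. One earlier swap on that same aromatic carbon, a 1.0-fold lower number from compound 2 to compound 3 (0.01 log units; within the scatter), moved nothing, and the larger replacements no change at the digits printed from compound 1 to compound 2 (within the scatter) and a 1.0-fold lower number from compound 1 to compound 3 (0.01 log units; within the scatter) stayed flat too. So no step beyond the scatter is expected, and the expected step is no change at the digits printed from compound 3 to compound 4 (within the scatter). Compound 4 is therefore estimated at 600 nM, with a likely range from 300 nM to 1200 nM.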

Compound 4, half-maximal inhibitory concentration: 170 nM
Estimate against measurement, compound 4: 3.5-fold (0.55 log units) above; the whole stated range lies above it.
By their numbers in this assay, from the lowest: compound 4; then compounds 3, 1 and 2 (each within the scatter of the next).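

At this para position, the identity of the small group does matter in this assay: ethyl lowers the number (a 3.5-fold lower number from compound 3 to compound 4 (0.55 log units; beyond the scatter)), and the change from chloro is similar (a 3.6-fold lower number from compound 2 to compound 4 (0.55 log units; beyond the scatter)), although methoxy and chloro had been indistinguishable. Replacing the whole group on the chain carbon gives a comparable step (a 3.6-fold lower number from compound 1 to compound 4 (0.55 log units; beyond the scatter)), so among these four compounds, only compound 4 stands apart. Nothing available explains why ethyl differs from methoxy or chloro. Going by these compounds, whether a longer chain such as propyl would lower the number further remains open, as does the effect of an amine or a carboxylic acid at this position.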